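The source may report more compounds than this note shows. Statements on the series, on what has been measured and on what is new or still open speak of the compounds shown alone.

Measured compounds in the series:

- compound 1, `COC(=O)/C=C/c1cccc(N(Cc2ccc(-c3cc(Cl)ccc3OC)cc2)C(=O)C(C)C)c1`: 226 nM
- compound 2, `COC(=O)/C=C/c1cccc(N(Cc2ccc(-c3ccc(OC(F)(F)F)cc3)cc2)C(=O)C(C)C)c1`: 219 nM
- compound 3, `COC(=O)/C=C/c1cccc(N(Cc2ccc(/C=C/c3cccc(Cl)c3)cc2)C(=O)C(C)C)c1`: 164 nM

All three share one core and differ only in the aryl group on the benzyl side. In an assay on isolated protein with Bile acid receptor (Homo sapiens) as the target (a lower number here means that less compound is needed, a higher number that more compound is needed for the effect), compound 3 gives the lowest of the three numbers, but its separation from the others is small: a 1.3-fold lower number from compound 2 to compound 3 (0.13 log units; within the scatter) and a 1.4-fold lower number from compound 1 to compound 3 (0.14 log units; within the scatter), both within the scatter, so no order among compounds 1, 2 and 3 can be claimed. The step of a 1.0-fold lower number from compound 1 to compound 2 (0.01 log units; within the scatter) is likewise flat.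

Compound 4, `COC(=O)/C=C/c1cccc(N(Cc2ccc(/C=C/c3ccccc3)cc2)C(=O)C(C)C)c1`, has not yet been measured in this assay. It differs from compound 3 by hydrogen in place of chloro on an aromatic carbon. Going by the values given here, none of the measured steps is a chloro-to-hydrogen change on the distal ring; the three steps available all swap the whole aryl group and all fall within the scatter, which suggests this part of the molecule has tolerated substantial variation without moving the read-out. A single chlorine removal is a smaller change than any of those. The step from compound 3 to compound 4 is therefore expected to be a 1.4-fold higher number from compound 3 to compound 4 (0.15 log units; within the scatter), that is, no shift beyond the scatter in either direction. Compound 4 is estimated at 230 nM, with a range from 110 nM to 520 nM.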

Compound 4, half-maximal effective concentration: 65 nM
Estimate against measurement, compound 4: 3.5-fold (0.55 log units) above; the whole stated range lies above it.
By their numbers in this assay, from the lowest: compound 4; then compounds 3, 2 and 1 (each within the scatter of the next).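

In this assay, going by these compounds alone, replacing chloro with hydrogen on the aromatic carbon meta to a large group gives the first step that lies beyond the scatter (a 2.5-fold lower number from compound 3 to compound 4 (0.40 log units; beyond the scatter)), although the whole-group swaps among compounds 1, 2 and 3 all stayed within it. Within the data shown here, the 2-phenylethenyl group also separates from the 4-(trifluoromethoxy)phenyl group (a 3.4-fold lower number from compound 2 to compound 4 (0.53 log units; beyond the scatter)) and from the 5-chloro-2-methoxyphenyl group (a 3.5-fold lower number from compound 1 to compound 4 (0.54 log units; beyond the scatter)), so this end of the molecule is less indifferent to change than the earlier compounds suggested, and a single chlorine on the 3-chlorophenyl ring is enough to register in the read-out. No available measurement accounts for this step.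

Open, on these data alone, is whether hydrogen is specifically preferred at this carbon or chloro is a poor fit there, which a fluoro, methyl, methoxy or amine at the same carbon would help separate. Also open, as far as these compounds go, is whether the step from 3-chlorophenyl to phenyl holds when the methyl ester of the shared core is replaced by a carboxylic acid.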